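A Bromine on the Pendant Phenyl of a Bis-enone

A few compounds are considered here, and "the series" means these few. Any claim that something is new, unique, unknown or untested is made for them only; others in the source may bear on it.

Compound 1 `Cc1cc(O)c(C(=O)/C=C/c2ccccc2)c(-c2ccccc2)c1C(=O)/C=C/c1ccccc1` is a doubly unsaturated ketone carrying a free hydroxyl and a pendant phenyl ring on its core. In a functional assay on MCF7 cells (Homo sapiens) for cytotoxicity, read by MTT assay, with a stated time of 24 h (a lower number here means a stronger inhibitor, a higher number a weaker inhibitor), compound 1 gives 10000 nM. Its closest neighbour, compound 2 `Cc1cc(O)c(C(=O)/C=C/c2ccc(Cl)cc2)c(-c2ccccc2)c1C(=O)/C=C/c1ccc(Cl)cc1`, carries two chloro groups where compound 1 has hydrogens, and in this assay compound 2 gives 10000 nM; the two values sit level with each other, within the scatter. Compound 3 `Cc1cc(O)c(C(=O)/C=C/c2ccccc2)c(-c2ccc(Br)cc2)c1C(=O)/C=C/c1ccccc1` has not yet been measured. It differs from compound 1 by bromo in place of hydrogen on an aromatic carbon, a bromo in place of hydrogen on an aromatic carbon. Going by the values given here, nothing measured so far shows any shift from placing halogens on the aromatic rings, so the step from compound 1 to compound 3 is expected to stay within the scatter, with no clear direction. Compound 3 is expected to give about 9000 nM in this assay, with a range from 4000 nM to 20000 nM. The expected step is a 1.1-fold lower number from compound 1 to compound 3 (0.05 log units; within the scatter).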

Compound 3, half-maximal inhibitory concentration: 10000 nM
The estimate for compound 3 lay 1.1-fold (0.05 log units) below the measured number, and the stated range covers the measured number.
By their numbers in this assay, from the lowest: compounds 1, 2 and 3 (each within the scatter of the next).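

The bromo on the pendant phenyl, para to a large group, leaves the reading in this assay unmoved, with no change at the digits printed from compound 1 to compound 3 (within the scatter) as the step. Going by these compounds alone, compound 2 carries its chloro groups elsewhere on the molecule, so this is the first look at a change on the pendant phenyl itself, and phenyl to 4-bromophenyl makes no visible difference at this position. Nothing measured here offers an explanation for this flat result.

From the compounds shown here alone, it remains open whether a different group on the pendant phenyl, such as an amine or a carboxylic acid, would shift the number in this assay. Going by these compounds, it is also open whether replacing the free hydroxyl on the shared core with a methoxy group would change the reading.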